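This account rests on a few compounds, and the source may have more. Where it says the series, first, only, none or still open, it means among the compounds named here.

Working notes on the series in an ADME assay on HFF cells (Homo sapiens) for cytotoxicity, with a stated time of 8 days; on this read-out lower numbers stand for higher toxicity in this test and higher numbers for lower toxicity in this test. Compound 1 `Nc1nc(NCc2ccccc2)c2ncn(/C=C3/CC3(CO)CO)c2n1` reads > 300000 nM, which is a limit and not a number. Compound 2 `CCCCCCSc1nc(N)nc2c1ncn2/C=C1/CC1(CO)CO` reads > 300000 nM, again a limit. Compound 3 `CCCCCCOc1nc(N)nc2c1ncn2/C=C1/CC1(CO)CO` reads > 200000 nM, also a limit. Compound 3 therefore stands at the limit of > 200000 nM in this assay, at which 1 of the 3 values shown sits. The other two compounds stand at the limit of > 300000 nM in this assay, at which 2 of the 3 values shown sit. No exact value is available anywhere in the series.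

Compound 4 `Nc1nc(SCc2ccccc2)c2ncn(/C=C3/CC3(CO)CO)c2n1` has not been measured. Relative to compound 3 it carries benzylsulfanyl in place of hexyloxy on an aromatic carbon. It pairs the benzyl group of compound 1 with the sulfur link of compound 2.

Going by the values given here, three measured steps bear on this change: a step that the two limits leave unreadable from compound 2 to compound 3, a step that the two limits leave unreadable from compound 1 to compound 2 and a step that the two limits leave unreadable from compound 1 to compound 3. None of them has a size that can be carried over to the new compound, and none gives a direction. In this assay, no step beyond the scatter is therefore expected, though this is a weak expectation resting only on limits. The expected step is a step that the limit leaves unreadable from compound 3 to compound 4. For compound 4 the estimated value is 250000 nM, with an expected range of 100000 nM to 400000 nM, and the read-out will probably be reported only as a limit.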

Compound 4, half-maximal cytotoxic concentration: > 300000 nM
Compound 4 gave a limit, no number; the forecaster's own chance of this, stated with the estimate: 75%; at least 1.2-fold (0.07 log units) between middle value and limit.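

In this assay compound 4 reads > 300000 nM, which is a limit. Going by these compounds alone, its steps from compound 1, compound 2 and compound 3 therefore cannot be read, and no new step follows. The compounds shown leave open how the benzylamino, hexylsulfanyl, hexyloxy and benzylsulfanyl groups compare in this read-out, with no exact value for any compound.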